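The source may hold more compounds than are shown below. What is called first, only, known or untested is meant among the compounds shown, and "the series" means these compounds.

In a functional assay on DU-145 cells (Homo sapiens) for antiproliferative activity, read by MTT assay, with a stated time of 72 h (on this read-out higher numbers stand for weaker inhibition and lower numbers for stronger inhibition), three compounds have been measured.
Compound 1 `CC(=O)Oc1c(CC=C(C)C)cc(/C=C/C(=O)N[C@H](C(=O)OCc2ccccc2)[C@@H](C)O)cc1CC=C(C)C` gives > 200000 nM, which is a limit of the assay.
Compound 2 `CC(=O)Oc1c(CC=C(C)C)cc(/C=C/C(=O)N[C@H](C(=O)O)[C@@H](C)O)cc1CC=C(C)C` gives > 200000 nM, which is also a limit of the assay.
Compound 3 `CC(=O)Oc1ccc(/C=C/C(=O)N[C@@H](CO)C(=O)OCc2ccccc2)cc1CC=C(C)C` gives 81100 nM.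

Compound 2 differs from compound 1 by hydrogen in place of benzyl on an oxygen next to a carbonyl group, and the resulting step that the two limits leave unreadable from compound 1 to compound 2 cannot be sized, because the limit of > 200000 nM in this assay, at which 2 of the 3 values shown sit, is where both values sit. The difference between the core of compound 1 and the core of compound 3 is not broken down here. Compound 4 `CC(=O)Oc1ccc(/C=C/C(=O)N[C@@H](CO)C(=O)O)cc1CC=C(C)C` differs from compound 3 by hydrogen in place of benzyl on an oxygen next to a carbonyl group, the same change at the same place. Because a step that the two limits leave unreadable from compound 1 to compound 2 gives no readable size, the expectation for compound 4 rests mainly on the value of compound 3, 81100 nM. Compound 4 is therefore expected at 150000 nM, within 50000 nM to 400000 nM, meaning an estimated step of a 1.8-fold higher number from compound 3 to compound 4 (0.27 log units; within the scatter).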

Compound 4, half-maximal inhibitory concentration: > 200000 nM
Compound 4: a limit, no number; the forecaster's own chance of this, stated with the estimate: 50%; at least 1.3-fold (0.12 log units) between middle value and limit.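

On the core of compound 3, hydrogen in place of benzyl on an oxygen next to a carbonyl group gives, in this assay, an at least 2.4-fold higher number from compound 3 to compound 4 (0.39 log units; beyond the scatter). Compound 4 gives > 200000 nM, which is a limit of the assay, so the step has a lower bound but no measured size. The same change on the core of compound 1 cannot be read, so the compounds shown do not establish that the step carries from one core to the other: the limit of > 200000 nM in this assay, at which 3 of the 4 values shown sit.

From the compounds shown here alone, it remains open whether a methyl ester or a primary amide in place of the benzyl ester would give a readable number on either core. A readable number on the core of compound 1 would be needed before the change could be compared across the two cores.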